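Swapping the Aryl Group on a Naphthyl Semicarbazone

This account rests on a few compounds, and the source may have more. Where it says the series, first, only, none or still open, it means among the compounds named here.

Measured so far:
Compound 1 `COc1cccc(/C=N/NC(=O)Nc2cccc3ccccc23)c1` gives 300 mg/kg in a functional assay on the whole organism (strain Swiss albino) with Mus musculus as the target, in the maximal electroshock model, with a stated time of 4 h; on this read-out higher numbers stand for an effect only at larger amounts of compound and lower numbers for an effect already at smaller amounts.
Compound 2 `C/C(=N\NC(=O)Nc1cccc2ccccc12)c1ccc(Cl)cc1` gives 300 mg/kg in this assay.
Compound 3 `C/C(=N\NC(=O)Nc1cccc2ccccc12)c1ccc(Cl)cc1Cl` gives 300 mg/kg in this assay.

Compound 1 stands level with compound 2 and compound 3 on the numbers shown. Compound 4 `O=C(N/N=C/c1ccc(Cl)cc1)Nc1cccc2ccccc12` differs from compound 1 in one place: 4-chlorophenyl in place of 3-methoxyphenyl on a carbon with a double bond to nitrogen. For the measured compounds named here, no measured step covers exactly this exchange. Going by the values given here, the only measured step, no change at the digits printed from compound 2 to compound 3 (within the scatter), adds chloro in place of hydrogen on an aromatic carbon and leaves the dose unchanged within the scatter. Compound 2 also carries 4-chlorophenyl on a carbon with a double bond to nitrogen and sits at the same dose as compound 1. The step of no change at the digits printed from compound 1 to compound 4 (within the scatter) is therefore expected to stay within the scatter. Compound 4 is estimated to need 300 mg/kg, with a range from 100 mg/kg to 600 mg/kg.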

Compound 4, minimum effective dose: 300 mg/kg
For compound 4 middle estimate and measured number coincide at the digits printed; low and high end bracket the measured number.
By their numbers in this assay, from the lowest: compounds 1, 2, 3 and 4 (each within the scatter of the next).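

In this assay the step of no change at the digits printed from compound 1 to compound 4 (within the scatter) replaces a whole aryl group, where the earlier step only added a chloro. At this carbon, the methoxy oxygen with its hydrogen-bond acceptor can therefore give way to a chlorine with no change in dose beyond the scatter. Nothing at hand explains this result. The compounds shown carry only substituted phenyl groups here, so the effect of an amine, a carboxylic acid or a longer chain at this carbon stays open. Also open, on these data alone, is which group, if any, would give an effect at a smaller dose.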